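Morpholine for pyrrolidine on the ester-linked amide

The source may hold more compounds than are shown below. What is called first, only, known or untested is meant among the compounds shown, and "the series" means these compounds.

Compounds measured:
compound 1, `CCOc1cc(NC(=O)C2(NC(=O)c3ccc4c(C5CCCC5)c(-c5ncc(Cl)cn5)n(C)c4c3)CCC2)ccc1/C=C/C(=O)OCC(N)=O`, < 200000 ug/mL
compound 2, `CCCN(C)C(=O)COC(=O)/C=C/c1ccc(NC(=O)C2(NC(=O)c3ccc4c(C5CCCC5)c(-c5ncc(Cl)cn5)n(C)c4c3)CCC2)cc1OCC`, < 200000 ug/mL
compound 3, `CCOc1cc(NC(=O)C2(NC(=O)c3ccc4c(C5CCCC5)c(-c5ncc(Cl)cn5)n(C)c4c3)CCC2)ccc1/C=C/C(=O)OCC(=O)N1CCCC1`, 200000 ug/mL

Of the compounds shown here, three sharing one core have been measured in an ADME assay for solubility; on this read-out higher numbers stand for higher solubility and lower numbers for lower solubility. Compound 1 `CCOc1cc(NC(=O)C2(NC(=O)c3ccc4c(C5CCCC5)c(-c5ncc(Cl)cn5)n(C)c4c3)CCC2)ccc1/C=C/C(=O)OCC(N)=O` gives < 200000 ug/mL, which is a limit of the assay and not a number. Compound 2 `CCCN(C)C(=O)COC(=O)/C=C/c1ccc(NC(=O)C2(NC(=O)c3ccc4c(C5CCCC5)c(-c5ncc(Cl)cn5)n(C)c4c3)CCC2)cc1OCC` likewise gives < 200000 ug/mL, again a limit. Going by the values given here, compound 3 `CCOc1cc(NC(=O)C2(NC(=O)c3ccc4c(C5CCCC5)c(-c5ncc(Cl)cn5)n(C)c4c3)CCC2)ccc1/C=C/C(=O)OCC(=O)N1CCCC1` gives 200000 ug/mL, the only number among the three. Compound 1 and compound 2 each sit at a limit, so compound 3 stands at or above everything shown.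

The steps among them are a step that the two limits leave unreadable from compound 1 to compound 2, a number no lower from compound 1 to compound 3 (the limit leaves the size open) and a number no lower from compound 2 to compound 3 (the limit leaves the size open); none of them has a readable size, because of the limit of < 200000 ug/mL in this assay, at which 2 of the 3 values shown sit.

Compound 4 `CCOc1cc(NC(=O)C2(NC(=O)c3ccc4c(C5CCCC5)c(-c5ncc(Cl)cn5)n(C)c4c3)CCC2)ccc1/C=C/C(=O)OCC(=O)N1CCOCC1` differs from compound 3 by morpholin-4-yl in place of pyrrolidin-1-yl on a carbonyl carbon. The measured steps all concern the group on that same carbonyl carbon, yet their sizes are hidden by the limit, so no size can be carried over. Compound 4 is therefore expected to stay close to compound 3, with an estimated step of no change at the digits printed from compound 3 to compound 4 (within the scatter) in this assay and an estimate of 200000 ug/mL, between 80000 ug/mL and 200000 ug/mL.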

Compound 4, solubility: < 30000 ug/mL
Compound 4 gave a limit, no number; the forecaster's own chance of this, stated with the estimate: 60%; middle value at least 6.6-fold (0.82 log units) from the limit.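

In this assay, going by these compounds alone, morpholin-4-yl in place of pyrrolidin-1-yl on a carbonyl carbon gives an at least 6.6-fold lower number from compound 3 to compound 4 (0.82 log units; beyond the scatter), the first step at this position with a readable size. Compound 4 gives < 30000 ug/mL, which is a limit of the assay and not a number. The group on this carbonyl carbon can therefore shift the read-out beyond the scatter, and exchanging one non-aromatic ring for another is enough to do so.

Going by these compounds, the steps from compound 1 and from compound 2 to compound 4 cannot be read, so how morpholin-4-yl compares with amino and methyl(propyl)amino remains open. Also open, on these data alone, is whether the change follows the larger ring or its ring oxygen, which a piperidin-1-yl group on the same carbonyl carbon could separate.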